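Methyl on a Shared Core and Cell Toxicity

The compounds below may be only part of what the source reports. "The series", "measured", "known", "first", "only" and "open" are said of these compounds alone.

Compound 1 `CC1CCCCN1c1nc(Cc2c(F)cccc2F)cc(=O)[nH]1` and compound 2 `O=c1cc(Cc2c(F)cccc2F)nc(N2CCC3(CC2)OCCO3)[nH]1` share a core carrying a 2,6-difluorobenzyl group; the difference between the two cores is not broken down here. Compound 3 `Cc1c(Cc2c(F)cccc2F)nc(N2CCCCC2C)[nH]c1=O` and compound 4 `Cc1c(Cc2c(F)cccc2F)nc(N2CCC3(CC2)OCCO3)[nH]c1=O` each add a methyl to that core. In an ADME assay on MT4 cells (Homo sapiens) for cytotoxicity, read by MTT assay, with a stated time of 4 days (on this read-out lower numbers stand for higher toxicity in this test and higher numbers for lower toxicity in this test), compound 1 gives > 78000 nM, which is a limit of the test and not a number. In this assay compound 2 gives > 69000 nM, also a limit. In this assay compound 3 gives 75000 nM. The change methyl in place of hydrogen on an aromatic carbon thus made an at least 1.0-fold lower number from compound 1 to compound 3 (0.01 log units; that floor lies within the scatter). The change methyl in place of hydrogen on an aromatic carbon is the same kind of change, though here the methyl sits ortho to a 2,6-difluorobenzyl group and para to a large group, where in compound 3 it sits para to a 2-methylpiperidin-1-yl group. A step that the limit leaves unreadable from compound 2 to compound 4 is expected, resting on the measured step of an at least 1.0-fold lower number from compound 1 to compound 3 (0.01 log units; that floor lies within the scatter). Compound 4 is therefore estimated at 75000 nM.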

Compound 4, half-maximal cytotoxic concentration: > 66000 nM
Compound 4 gave a limit, no number (the forecaster's own chance of this, stated with the estimate: 60%); the middle value lies beyond the limit too.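

Among these compounds, no step from compound 2 to compound 4 can be read in this assay: each gave only a limit of the test, not a number. Going by these compounds, whether this methyl changes toxicity to these cells at all remains open.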